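Oxadiazole series: allylamino to ethylamino step

A few compounds are considered here, and "the series" means these few. Any claim that something is new, unique, unknown or untested is made for them only; others in the source may bear on it.

In a functional assay on the whole organism (strain BALB/c) for inhibition, with Mus musculus as the target, read by paw edema, with a stated time of 4 h, at a dose of 50 mg/kg by the oral route (a higher number here means more inhibition at the dose given (going by the name of the read-out), a lower number less inhibition), compound 1 `CCNc1nnc(-c2cc(-c3ccc(F)cc3F)ccc2O)s1` gives 50.2%. Compound 2 `C=CCNc1nnc(-c2cc(-c3ccc(F)cc3F)ccc2O)o1` gives 36.6% in this assay, the lowest of the two numbers shown, with compound 1 standing above it by more than the scatter. Compound 3 `CCNc1nnc(-c2cc(-c3ccc(F)cc3F)ccc2O)o1` has not been measured in this assay; it differs from compound 2 by methyl in place of vinyl on a saturated chain carbon bound to a nitrogen on an aromatic ring. Among the compounds with values here, no measured pair shows this exact change, so its effect is unknown. A small change is expected, leaning upward, as compound 1 with an ethylamino group gives 50.2%. Compound 3 is therefore estimated at 42%, with a range of 28% to 56%, a step of a number 5.4 percentage points higher from compound 2 to compound 3 (within the scatter) that is expected to stay near the scatter.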

Compound 3, a percentage reported as inhibition, in the whole organism at one dose (the size of the read-out at that dose, not a potency): 36.8%
Compound 3: the middle estimate sits 5.2 percentage points above what was measured; the range from low to high includes it.
By their numbers in this assay, from the lowest: compounds 2 and 3 (each within the scatter of the next); then compound 1.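

In this assay, within the data shown here, the change from allylamino to ethylamino gives a number 0.2 percentage points higher from compound 2 to compound 3 (within the scatter) and is the first measured pair at this place, on a saturated chain carbon bound to a nitrogen on an aromatic ring. At this dose, the read-out does not separate vinyl from methyl here. Nothing at hand bears on a cause for this result.

From the compounds shown here alone, whether a longer chain, a cyclopropyl group or an unsubstituted amine at this place would move the read-out remains open. Also open, going by these compounds, is whether allylamino and ethylamino would read alike on the core of compound 1.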